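The source may hold more compounds than are shown below. What is called first, only, known or untested is meant among the compounds shown, and "the series" means these compounds.

Compound 1 `COc1cc(/C=C/C(=O)c2cccc(-n3cc(-c4ccc(Cl)cc4)[nH]c3=O)c2)cc(OC)c1OC`: 5140 nM
Compound 2 `COc1cc(/C=C/C(=O)c2cccc(-n3cc(-c4ccccc4)[nH]c3=O)c2)ccc1O`: 3310 nM
Compound 3 `O=C(/C=C/c1cccc(O)c1)c1cccc(-n2cc(-c3ccccc3)[nH]c2=O)c1`: 3140 nM

In a functional assay on SN12C cells (Homo sapiens) for inhibition (a higher number here means a weaker inhibitor of growth, a lower number a stronger inhibitor of growth), compound 1 gives 5140 nM and lies within the scatter of both compound 2 and compound 3. Compound 4 `COc1ccc(-c2cn(-c3cccc(C(=O)/C=C/c4cc(OC)c(OC)c(OC)c4)c3)c(=O)[nH]2)cc1` differs from compound 1 as follows: methoxy in place of chloro on an aromatic carbon. In words, 4-chlorophenyl becomes 4-methoxyphenyl. Among the compounds with values here, no measured step covers this exchange. Within the data shown here, the only measured step, a 1.1-fold lower number from compound 2 to compound 3 (0.02 log units; within the scatter), involves a different place and offers no sign of a large shift. No step beyond the scatter is therefore expected, and the expected step is a 1.1-fold lower number from compound 1 to compound 4 (0.06 log units; within the scatter) in this assay, with no direction favoured. For compound 4 the estimated value is 4500 nM, with an expected range of 1800 nM to 11000 nM.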

Compound 4, concentration for 50% growth inhibition: 3500 nM
Compound 4: middle estimate off by 1.3-fold (0.11 log units), on the high side, and the stated range covers the measured number.
By their numbers in this assay, from the lowest: compounds 3, 2, 4 and 1 (each within the scatter of the next).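

In this assay, within the data shown here, the exchange of chloro for methoxy on an aromatic carbon para to a large group gives a 1.5-fold lower number from compound 1 to compound 4 (0.17 log units; within the scatter), the only measured step at this position. Chloro and methoxy are therefore not told apart here, although methoxy adds a hydrogen-bond acceptor. No evidence on hand bears on this result.

On these data alone, whether an amine or a carboxylic acid in place of methoxy would move the number beyond the scatter stays open. No step shown lies beyond the scatter, so which part of the structure governs growth inhibition also stays open.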